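The compounds below may be only part of what the source reports. "The series", "measured", "known", "first", "only" and "open" are said of these compounds alone.

Values in a functional assay on MCF7 cells (Homo sapiens) for antiproliferative activity, read by sulforhodamine B assay, with a stated time of 48 h; on this read-out lower numbers stand for stronger inhibition and higher numbers for weaker inhibition:

- compound 1 `CCCN1CCN(c2ccc(S(=O)(=O)Oc3cccc(F)c3)cc2)C1=O`: 24000 nM
- compound 2 `CCCCN1CCN(c2ccc(S(=O)(=O)Oc3ccccc3OC)cc2)C1=O`: 3800 nM
- compound 3 `CCCCN1CCN(c2ccc(S(=O)(=O)Oc3cccc(F)c3)cc2)C1=O`: 310 nM

Among these three, compound 3 gives the lowest number, 310 nM, in this assay. Its two measured neighbours both sit well above it, as a 12-fold lower number from compound 2 to compound 3 (1.09 log units; beyond the scatter) and a 77-fold lower number from compound 1 to compound 3 (1.89 log units; beyond the scatter) show.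

Compound 4 `CCCCN1CCN(c2ccc(S(=O)(=O)Oc3cc(F)cc(F)c3)cc2)C1=O` departs from compound 3 by one change, fluoro in place of hydrogen on an aromatic carbon, turning 3-fluorophenyl into 3,5-difluorophenyl.

The closer precedent is a 12-fold lower number from compound 2 to compound 3 (1.09 log units; beyond the scatter), a large step at the same aryl group, though it replaces the whole group rather than adding one fluoro. The other large step, a 77-fold lower number from compound 1 to compound 3 (1.89 log units; beyond the scatter), lies on the saturated chain, which stays untouched here, so it bears little on this change. Among the measured compounds shown here, no measured step isolates a single added fluoro, so a far smaller move is expected, with its direction uncertain and nothing beyond the scatter anticipated.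

The expected step is a 1.2-fold lower number from compound 3 to compound 4 (0.08 log units; within the scatter). For compound 4 the estimated value is 260 nM, with an expected range of 70 nM to 1000 nM.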

Compound 4, half-maximal inhibitory concentration: 400 nM
For compound 4 the middle estimate is 1.5-fold (0.19 log units) below the measured one; measured number inside the range.
By their numbers in this assay, from the lowest: compounds 3 and 4 (each within the scatter of the next); then compound 2; then compound 1.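

Adding a second fluoro to the aryl group, turning 3-fluorophenyl into 3,5-difluorophenyl, leaves the read-out in this assay within the scatter, as (a 1.3-fold higher number from compound 3 to compound 4 (0.11 log units; within the scatter)) shows, so this aromatic carbon accepts a fluoro without a measurable loss or gain. The earlier compounds shown here showed only that replacing the whole aryl group could matter; the 3,5-difluorophenyl group now also stands well clear of 2-methoxyphenyl, with (a 9.5-fold lower number from compound 2 to compound 4 (0.98 log units; beyond the scatter)) beyond the scatter, much like the 3-fluorophenyl group in (a 12-fold lower number from compound 2 to compound 3 (1.09 log units; beyond the scatter)). Nothing shown gives a reason for this result.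

On these data alone, what a chloro or a methoxy group would do at this aromatic carbon remains open. So does whether a longer chain on the shared core would lower the number further, or whether the added fluoro would stay as silent alongside the shorter chain of compound 1.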